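Compound 4 and the Sulfonyl Sulfur Exchange

This account rests on a few compounds, and the source may have more. Where it says the series, first, only, none or still open, it means among the compounds named here.

Compound 1 `Cc1ccc(CS(=O)(=O)/C(=C/c2ccc(Br)cc2)C(=O)c2ccc(Cl)cc2)cc1`: 25000 nM
Compound 2 `CCOc1ccc(/C=C(\C(=O)c2ccc(Cl)cc2)S(=O)(=O)Cc2ccc(C)cc2)cc1OC`: 10000 nM
Compound 3 `O=C(/C(=C\c1ccc(Cl)cc1)S(=O)(=O)c1ccc(Cl)cc1)c1ccc(Cl)cc1`: 25000 nM

In a functional assay on DU-145 cells (Homo sapiens) for inhibition, read by trypan blue exclusion, with a stated time of 96 h (on this read-out higher numbers stand for weaker inhibition of growth and lower numbers for stronger inhibition of growth), compound 3 gives 25000 nM, and compound 1 gives the same number at the digits shown, while compound 2 lies lower at 10000 nM. Compound 4 `Cc1ccc(CS(=O)(=O)/C(=C/c2ccc(Cl)cc2)C(=O)c2ccc(Cl)cc2)cc1` is reached from compound 3 by placing 4-methylbenzyl in place of 4-chlorophenyl on a sulfonyl sulfur.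

Among the measured compounds shown here, no measured pair isolates this exchange. For the measured compounds named here, the only measured step, a 2.5-fold lower number from compound 1 to compound 2 (0.40 log units; beyond the scatter), is modest and falls elsewhere on the molecule, so it says little about the sulfonyl sulfur. More useful is compound 1, which already carries 4-methylbenzyl on that sulfur and gives 25000 nM, level with compound 3. Neither neighbour therefore points to a clear shift in either direction, and both lie at the weak end of the three numbers. In this assay the expected step is a 1.3-fold lower number from compound 3 to compound 4 (0.10 log units; within the scatter), which would stay within the scatter. For compound 4 the estimated value is 20000 nM, with an expected range from 9000 nM to 40000 nM.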

Compound 4, concentration for 50% growth inhibition: 25000 nM
Compound 4: the middle estimate sits 1.3-fold (0.10 log units) below what was measured, within the range that was stated.
By their numbers in this assay, from the lowest: compound 2; then compounds 1, 3 and 4 (each within the scatter of the next).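

In this assay, the sulfonyl sulfur exchange can now be read on its own: 4-methylbenzyl in place of 4-chlorophenyl gives no change at the digits printed from compound 3 to compound 4 (within the scatter), so among these compounds the group on that sulfur can be swapped without a detectable shift in the number. Chloro in place of bromo on an aromatic carbon likewise gives no change at the digits printed from compound 1 to compound 4 (within the scatter), whereas 4-chlorophenyl in place of 4-ethoxy-3-methoxyphenyl on a double-bonded chain carbon bound to a double-bonded chain carbon gives a 2.5-fold higher number from compound 2 to compound 4 (0.40 log units; beyond the scatter), so this is the one new step here that lies beyond the scatter. Nothing available explains why the sulfur exchange leaves the number in place or why the other exchange moves it.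

Going by these compounds, the sulfonyl sulfur is seen here with only 4-chlorophenyl and 4-methylbenzyl, so it remains open whether an aminoalkyl chain or a carboxylic acid on that sulfur would also leave the number in place. On these data alone, the 4-ethoxy-3-methoxyphenyl group appears only with 4-methylbenzyl on the sulfur, so it also remains open whether its step would hold with 4-chlorophenyl there.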